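This account rests on a few compounds, and the source may have more. Where it says the series, first, only, none or still open, it means among the compounds named here.

Measured in a functional assay on MCF7 cells (Homo sapiens) for cytotoxicity, read by MTT assay; on this read-out higher numbers stand for weaker inhibition and lower numbers for stronger inhibition:
- compound 1 `Oc1ccc(CN(Cc2ccccc2C(F)(F)F)Cc2ccc(O)c3ncccc23)c2cccnc12`: 88 nM
- compound 2 `Oc1ccc(CN(Cc2cccs2)Cc2ccc(O)c3ncccc23)c2cccnc12`: 35 nM

Compound 2 holds the lower of these two numbers in this assay. Compound 3 `O=C(O)C1CCC(CN(Cc2ccc(O)c3ncccc23)Cc2ccc(O)c3ncccc23)CC1` has not yet been measured. Its change is 4-carboxycyclohexyl in place of thiophen-2-yl on a saturated chain carbon bound to an amine nitrogen.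

Among the measured compounds shown here, only one measured step bears on this place: a 2.5-fold lower number from compound 1 to compound 2 (0.40 log units; beyond the scatter). For the measured compounds named here, it is modest, and no measured compound carries a group like the entering one, so the evidence is thin. The change removes the group of compound 2, which stands at 35 nM, so a modest or somewhat larger move towards a higher number is expected. The expected change is a 3.4-fold higher number from compound 2 to compound 3 (0.54 log units; beyond the scatter). For compound 3, the estimated value is 120 nM, within an expected range of 30 nM to 500 nM.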

Compound 3, half-maximal inhibitory concentration: 9460 nM
Estimate against measurement, compound 3: 79-fold (1.90 log units) below, outside the stated range (above it).
By their numbers in this assay, from the lowest: compound 2; then compound 1; then compound 3.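

In this assay, this position tolerates far less than the earlier pair showed: 4-carboxycyclohexyl in place of thiophen-2-yl gives a 270-fold higher number from compound 2 to compound 3 (2.43 log units; beyond the scatter), and in place of 2-(trifluoromethyl)phenyl it gives a 110-fold higher number from compound 1 to compound 3 (2.03 log units; beyond the scatter). Both steps are large, whereas the exchange between the two aromatic groups was only modest, at a 2.5-fold lower number from compound 1 to compound 2 (0.40 log units; beyond the scatter), so the group on this saturated chain carbon bound to an amine nitrogen can move the number much further than that pair revealed. No measurement at hand explains this loss.

The compounds shown leave open whether the shift is tied to the carboxylic acid or to the non-aromatic ring, as 4-carboxycyclohexyl differs from the groups it replaces in both. An unsubstituted cyclohexyl and a phenyl bearing a carboxylic acid would separate the two.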